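A few compounds are considered here, and "the series" means these few. Any claim that something is new, unique, unknown or untested is made for them only; others in the source may bear on it.

Among the measured compounds shown here, compound 1 `CC(C)(CO)S(=O)(=O)c1cccc(NC(=O)c2cccnc2N2CCC3(CC2)CC3)c1` is one of two compounds so far measured in an ADME assay on microsomes from liver (Mus musculus) for metabolic stability, read by LC-MS, with a stated time of 40 min, tested at 0.5 uM; a higher number here means faster removal of the compound, a lower number slower removal. In this assay compound 1 reaches only a limit of the method, > 399 mL.min-1.g-1. Compound 1 thus sits at the limit of > 399 mL.min-1.g-1 in this assay, at which 1 of the 2 values shown sits. The other measured compound, compound 2 `CC(C)(C)NS(=O)(=O)c1cccc(NC(=O)c2ncc(NC(C)(C)CO)nc2N2CCC3(CC2)CC3)c1`, gives 76 mL.min-1.g-1 in this assay. Compound 3 `CC(C)S(=O)(=O)c1cccc(NC(=O)c2cccnc2N2CCC3(CC2)CC3)c1` has not yet been measured; it differs from compound 1 by hydrogen in place of hydroxymethyl on a saturated chain carbon bound to two saturated chain carbons and a sulfonyl sulfur. For the measured compounds named here, no step between measured compounds carries this change, so the expected step that the limit leaves unreadable from compound 1 to compound 3 is no more than the usual scatter. Compound 3 is therefore estimated at 400 mL.min-1.g-1, within 200 mL.min-1.g-1 to 900 mL.min-1.g-1.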

Compound 3, intrinsic clearance in microsomes: > 399 mL.min-1.g-1
Compound 3: only a limit was reported; the forecaster's own chance of this, stated with the estimate: 60%; the middle value does not contradict the limit.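

Compound 1 and compound 3 both stand at a limit in this assay, so no step between them can be read: the limit of > 399 mL.min-1.g-1 in this assay, at which 2 of the 3 values shown sit.
The compounds shown leave open how hydrogen in place of hydroxymethyl changes removal here.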